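This account rests on a few compounds, and the source may have more. Where it says the series, first, only, none or still open, it means among the compounds named here.

Measured compounds:
compound 1, `Cn1nc(-c2ccnc(Nc3cccc([N+](=O)[O-])c3)n2)c2ccccc21`, gives 490 nM
compound 2, `Cn1nc(-c2ccnc(Nc3cccc(S(N)(=O)=O)c3)n2)c2ccccc21`, gives 1980 nM
compound 3, `CCn1nc(-c2ccnc(Nc3ccc(S(N)(=O)=O)cc3)n2)c2ccccc21`, gives 2050 nM

These three were measured in a functional assay on HCT-116 cells (Homo sapiens) for antiproliferative activity, read by MTT assay, with a stated time of 72 h; on this read-out lower numbers stand for stronger inhibition of growth and higher numbers for weaker inhibition of growth. Compound 1 and compound 2 share one core and differ in a single place: nitro in place of sulfamoyl on an aromatic carbon. That change gave a 4.0-fold lower number from compound 2 to compound 1 (0.61 log units; beyond the scatter). Compound 3 carries a different core; how its core differs from that of compound 2 is not broken down here, and the values of compound 2 and compound 3 lie within the scatter of each other.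

Compound 4, `CCn1nc(-c2ccnc(Nc3ccc([N+](=O)[O-])cc3)n2)c2ccccc21`, has not yet been measured in this assay. It is made from compound 3 by the same kind of change seen from compound 2 to compound 1: nitro in place of sulfamoyl on an aromatic carbon. The two places are not identical in wording: in compound 1 the group sits meta to a large group, in compound 4 para to a large group. Because the same replacement gave a 4.0-fold lower number from compound 2 to compound 1 (0.61 log units; beyond the scatter), a step of similar size is expected here, so that compound 4 is estimated at a 3.7-fold lower number from compound 3 to compound 4 (0.57 log units; beyond the scatter). Compound 4 is therefore expected to give 550 nM, within 200 nM to 1500 nM.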

Compound 4, concentration for 50% growth inhibition: 4060 nM
Beside the measured number, compound 4's estimate is 7.4-fold (0.87 log units) below it; the measured number lies above the stated range.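

In this assay, among the compounds shown here, the replacement of sulfamoyl by nitro on the core of compound 3 gave a 2.0-fold higher number from compound 3 to compound 4 (0.30 log units; within the scatter), so on this core the change produced no step that stands clear of the scatter. Set beside the earlier step, this result shows that the step seen on one core did not carry over to the other: the same change on two cores in this assay, a 4.0-fold lower number (0.61 log units; beyond the scatter) from compound 2 to compound 1 and a 2.0-fold higher number (0.30 log units; within the scatter) from compound 3 to compound 4, 8.0-fold (0.90 log units) apart, beyond the scatter of two such steps The two pairs differ both in their cores and in where the group sits, so these data do not show which of the two accounts for the gap, and with only two pairs they give no general rule for this change in the series.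

The compounds shown leave open whether nitro and sulfamoyl would give matching steps on both cores if the group sat in the same place on each. They also leave open how a nitrile, a carboxylic acid or an amine would behave at this place, and what a longer chain on the core would do.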